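A few compounds are considered here, and "the series" means these few. Any claim that something is new, unique, unknown or untested is made for them only; others in the source may bear on it.

Measured compounds:
Compound 1, `O=C1N=C(C2C(=O)c3ccccc3C2=O)CC(c2ccc([N+](=O)[O-])cc2)N1`, giving 26%.
Compound 2, `O=C1N=C(C2C(=O)c3ccccc3C2=O)CC(c2ccc(Cl)cc2)N1`, giving 19%.
Compound 3, `CN(C)c1ccc(C2CC(C3C(=O)c4ccccc4C3=O)=NC(=O)N2)cc1`, giving 29%.

These values come from a functional assay on the whole organism for inhibition, with Rattus norvegicus as the target, read by paw edema, with stated times of 30 min and 2 h, at a dose of 10 mg/kg by the oral route; on this read-out higher numbers stand for more inhibition at the one dose given (going by the name of the read-out) and lower numbers for less inhibition. Compound 3 has the highest number of the three, but the step of a number 3 percentage points higher from compound 1 to compound 3 (within the scatter) and the step of a number 10 percentage points higher from compound 2 to compound 3 (within the scatter) are both within the scatter, as is the step of a number 7 percentage points lower from compound 1 to compound 2 (within the scatter), so no ordering of the three can be claimed.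

Compound 4, `O=C1N=C(C2C(=O)c3ccccc3C2=O)CC(c2ccccc2O)N1`, differs from compound 3 by 2-hydroxyphenyl in place of 4-(dimethylamino)phenyl on a saturated ring carbon. Every measured step exchanged one group for another on an aromatic carbon of the aryl group attached to the shared core, and each of those steps stayed within the scatter. Within the data shown here, the present change replaces the whole 4-(dimethylamino)phenyl group with 2-hydroxyphenyl, and no measured pair shows that kind of exchange, so the measured steps bear on it only loosely. Since the three measured values lie within scatter of one another, compound 4 is expected to show a step of a number 5 percentage points lower from compound 3 to compound 4 (within the scatter) that is not beyond the scatter. Compound 4 is therefore estimated at 24% in this assay, with a range from 10% to 38%.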

Compound 4, a percentage reported as inhibition, in the whole organism at one dose (the size of the read-out at that dose, not a potency): 22%
Estimate against measurement, compound 4: 2 percentage points above; the range from low to high includes it.
By their numbers in this assay, from the lowest: compounds 2, 4, 1 and 3 (each within the scatter of the next).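

In this assay, exchanging the whole aryl group on the saturated ring carbon, rather than one substituent on the phenyl ring, gives a number 7 percentage points lower from compound 3 to compound 4 (within the scatter) and a number 3 percentage points higher from compound 2 to compound 4 (within the scatter) and a number 4 percentage points lower from compound 1 to compound 4 (within the scatter) at this position. The earlier compounds shown here all carried a group on the phenyl ring at the same place, whereas compound 4 has 2-hydroxyphenyl, which counts a hydrogen-bond donor where 4-(dimethylamino)phenyl counts none, and this change does not separate it from the other three. Nothing available here accounts for the size of these steps.

As far as these compounds go, whether a cyclohexyl group in place of the aryl group, or a carboxylic acid or a primary amine on the phenyl ring, would move the read-out beyond the scatter remains open. With all four values within the scatter of one another at a single dose, neither an ordering of the compounds nor their potency can be stated.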